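Swapping Nitro for Fluoro: What to Expect of Compound 4

This account rests on a few compounds, and the source may have more. Where it says the series, first, only, none or still open, it means among the compounds named here.

compound 1 `COc1ccc(C(=O)/C=C/c2ccccc2[N+](=O)[O-])c(OC)c1OC` — 7000 nM
compound 2 `COc1ccc(C(=O)/C=C/c2ccccc2F)c(OC)c1OC` — 11000 nM
compound 3 `COc1ccc(C(=O)/C=C/c2cccc([N+](=O)[O-])c2)c(OC)c1OC` — 36000 nM

Of the compounds shown here, three have been measured in a functional assay (Homo sapiens) for inhibition; a lower number here means a stronger inhibitor, a higher number a weaker inhibitor. Compound 1 and compound 2 share a core and differ by fluoro in place of nitro on an aromatic carbon; this step, a 1.6-fold higher number from compound 1 to compound 2 (0.20 log units; within the scatter), lies within the scatter. Compound 3 has the same atoms as compound 1 joined differently; the difference between the two cores is not broken down here. Compound 3 shows the highest number of the three, beyond the scatter from both others. Compound 4 `COc1ccc(C(=O)/C=C/c2cccc(F)c2)c(OC)c1OC` has not yet been measured in this assay; it differs from compound 3 by fluoro in place of nitro on an aromatic carbon. Among the compounds with values here, this is the same kind of change as the one from compound 1 to compound 2, though the place differs: there the group sits ortho to a large group, here meta to a large group. Resting on a 1.6-fold higher number from compound 1 to compound 2 (0.20 log units; within the scatter), the step from compound 3 to compound 4 is expected to be a 1.3-fold higher number from compound 3 to compound 4 (0.10 log units; within the scatter). Compound 4 is therefore estimated at 45000 nM, between 15000 nM and 140000 nM.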

Compound 4, half-maximal inhibitory concentration: 6400 nM
Beside the measured number, compound 4's estimate is 7.0-fold (0.85 log units) above it; the whole stated range lies above it.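

In this assay, fluoro in place of nitro did not carry the same step from one core to the other: the same change on two cores in this assay, a 1.6-fold higher number (0.20 log units; within the scatter) from compound 1 to compound 2 and a 5.6-fold lower number (0.75 log units; beyond the scatter) from compound 3 to compound 4, 8.8-fold (0.95 log units) apart, beyond the scatter of two such steps. The change gives a 5.6-fold lower number from compound 3 to compound 4 (0.75 log units; beyond the scatter) on the core of compound 3, while 3-fluorophenyl in place of 2-fluorophenyl gives a 1.7-fold lower number from compound 2 to compound 4 (0.24 log units; within the scatter), so these two fluoro compounds are not told apart. A step read on one core therefore cannot simply be carried to the other in this series, but two pairs do not show why the steps differ, nor do they give a rule for other cores or groups.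

On these data alone, whether an amine or a carboxylic acid in the same places would follow the nitro or the fluoro compounds remains open. So does whether a chloro group would give a step like either of these two.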